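The source may hold more compounds than are shown below. What is called first, only, known or untested is meant among the compounds shown, and "the series" means these compounds.

Measured in a functional assay on MIA PaCa-2 cells (Homo sapiens) for inhibition, read by MTT assay, with a stated time of 72 h; on this read-out higher numbers stand for weaker inhibition of growth and lower numbers for stronger inhibition of growth:

compound 1 `O=S(=O)(NCCCCCCNCc1ccc(Br)cc1)c1ccc(C(F)(F)F)cc1` gives 3830 nM
compound 2 `O=S(=O)(NCCCNCc1ccc(C(F)(F)F)cc1)c1cc(C(F)(F)F)cc(C(F)(F)F)c1` gives 2500 nM
compound 3 `O=S(=O)(NCCCCCCNCc1ccc(Br)cc1)c1cccc(C(F)(F)F)c1` gives 5970 nM

Compound 1 sits in the middle of these three numbers; its number lies within the usual scatter of compound 2 on one side and of compound 3 on the other, so the three cannot be told apart on this read-out. Among the measured compounds shown here, no pair among them differs in a single place, so no step between measured compounds is available to set a scale for a change on the sulfonyl-bearing ring.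

Compound 4 `CC(C)c1ccc(S(=O)(=O)NCCCCCCNCc2ccc(Br)cc2)cc1` is the next compound, differing from compound 1 by isopropyl in place of trifluoromethyl on an aromatic carbon. With nothing measured on a change of this kind in the series, the expectation for the step from compound 1 to compound 4 in this assay is set at a 1.0-fold higher number from compound 1 to compound 4 (0.02 log units; within the scatter), that is, no step beyond the scatter in either direction. On that basis compound 4 is expected to give about 4000 nM in this assay, with a range from 1500 nM to 11000 nM.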

Compound 4, concentration for 50% growth inhibition: 5730 nM
For compound 4 the middle estimate is 1.4-fold (0.16 log units) below the measured one; the measured number falls inside the stated range.
By their numbers in this assay, from the lowest: compounds 2, 1, 4 and 3 (each within the scatter of the next, the first and the last beyond it).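

In this assay the series now has its first step at a single place on the sulfonyl-bearing ring: isopropyl in place of trifluoromethyl on an aromatic carbon, para to a large group, gives a 1.5-fold higher number from compound 1 to compound 4 (0.17 log units; within the scatter) and so leaves the two compounds indistinguishable on this read-out. At this position, trifluoromethyl and isopropyl therefore cannot be told apart, and this one step sets the only scale so far for a change here. No measured evidence on either group accompanies the step.

As far as these compounds go, whether a nitrile, an amine or a carboxylic acid at this place would give a step beyond the scatter remains open. Also open, from the compounds shown here alone, is whether isopropyl in place of trifluoromethyl would read the same way on a core with a longer chain.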